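Halogen swap on the urea aryl ring of compound 1

A few compounds are considered here, and "the series" means these few. Any claim that something is new, unique, unknown or untested is made for them only; others in the source may bear on it.

Compound 1 `O=C(Nc1cccc(CNc2nccnc2Cl)c1)Nc1ccc(F)c(Cl)c1`: 6750 nM
Compound 2 `O=C(Nc1ccc(C(F)(F)F)cc1)Nc1cccc(CNc2nccnc2Cl)c1`: 5050 nM
Compound 3 `CC(C)(C)c1ccc(NC(=O)Nc2cccc(CNc3nccnc3Cl)c2)cc1`: 7550 nM

Of the compounds shown here, three sharing one core have been measured in a functional assay on HepG2 cells (Homo sapiens) for antiproliferative activity, read by MTT assay, with a stated time of 48 h; on this read-out higher numbers stand for weaker inhibition and lower numbers for stronger inhibition. Compound 1 gives 6750 nM and holds the second highest of the three numbers; its nearest neighbour is compound 3 and its furthest is compound 2, and both gaps lie within the scatter. Among the measured compounds shown here, the only single-point step among them, a 1.5-fold higher number from compound 2 to compound 3 (0.17 log units; within the scatter), also lies within the scatter, so the three compounds are not separated by this assay.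

Compound 4 `O=C(Nc1cccc(CNc2nccnc2Cl)c1)Nc1ccc(Cl)c(Cl)c1` has not yet been measured. It differs from compound 1 by chloro in place of fluoro on an aromatic carbon. For the measured compounds named here, none of the measured steps touches this position or this pair of groups, so no direct precedent exists. Going by the values given here, since the one measured step stays within the scatter and the three values sit close together, the step of a 1.1-fold lower number from compound 1 to compound 4 (0.05 log units; within the scatter) is expected to stay within the scatter as well. Compound 4 is therefore estimated at 6000 nM, with a range from 3000 nM to 12000 nM.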

Compound 4, half-maximal inhibitory concentration: 6170 nM
For compound 4 the middle estimate is 1.0-fold (0.01 log units) below the measured one; the measured number falls inside the stated range.
By their numbers in this assay, from the lowest: compounds 2, 4, 1 and 3 (each within the scatter of the next).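

In this assay the change from 3-chloro-4-fluorophenyl to 3,4-dichlorophenyl gives (a 1.1-fold lower number from compound 1 to compound 4 (0.04 log units; within the scatter)), so this step does not separate compound 1 from compound 4. Among the compounds shown here, it is the first measured step at this position, on the aromatic carbon ortho to a chloro group and para to a large group, and it shows that this assay does not tell fluoro from chloro there. No measurement available here explains this result.

The compounds shown leave open whether an amine, a methoxy group or a carboxylic acid at this position would give a step beyond the scatter. They also leave open whether the same holds for these groups on a different core, since every compound shown shares the core of compound 1.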